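Rearranging the pendant group on the fused core

This account rests on a few compounds, and the source may have more. Where it says the series, first, only, none or still open, it means among the compounds named here.

Measured so far:
compound 1 `C=C(Br)C(=O)Nc1cccc(-c2cn3nc(-c4ccc(OCC)cc4)sc3n2)c1`: 1100 nM
compound 2 `Nc1cccc(-c2cn3nc(Cc4ccccc4)sc3n2)c1`: 24000 nM
compound 3 `Nc1cccc(-c2cn3c(-c4ccc(Cl)cc4)csc3n2)c1`: 17000 nM

In a functional assay on HeLa cells (Homo sapiens) for inhibition, read by cell counting, with a stated time of 4 days (on this read-out lower numbers stand for stronger inhibition and higher numbers for weaker inhibition), compound 1 gives 1100 nM, the lowest of the three numbers; compound 3 lies beyond the scatter above it, and compound 2 lies further beyond. Compound 2 and compound 3 lie within the scatter of each other.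

Compound 4 `C=C(Br)C(=O)Nc1cccc(-c2cn3nc(Cc4ccc(OC)cc4)sc3n2)c1` is not yet measured. It differs from compound 1 in one place: 4-methoxybenzyl in place of 4-ethoxyphenyl on an aromatic carbon. The same atoms are joined differently, so the change is one of arrangement only.

Among the compounds with values here, no comparable single step exists among the measured compounds, so the expectation rests on compound 1 alone. A modest loss is expected from compound 1 to compound 4, a 2.3-fold higher number from compound 1 to compound 4 (0.36 log units; beyond the scatter), with the result possibly still within the scatter. Compound 4 is estimated at 2500 nM, range 800 nM to 8000 nM.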

Compound 4, half-maximal inhibitory concentration: 2300 nM
Compound 4: the middle estimate sits 1.1-fold (0.04 log units) above what was measured; low and high end bracket the measured number.
By their numbers in this assay, from the lowest: compound 1; then compound 4; then compounds 3 and 2 (each within the scatter of the next).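

In this assay, replacing 4-ethoxyphenyl with 4-methoxybenzyl gives a 2.1-fold higher number from compound 1 to compound 4 (0.32 log units; beyond the scatter) and so costs only a modest amount, though the step lies beyond the scatter. Within the data shown here, this is the first single-place comparison, and it shows that this aromatic carbon of the shared core accepts a rearrangement of the same atoms with a modest loss. No measured information accounts for the size of this step.

Going by these compounds, it remains open which part of the change carries the step: the benzyl link or the shorter methoxy group. A 4-methoxyphenyl or 4-ethoxybenzyl group at this position would separate the two.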